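The source may report more compounds than this note shows. Statements on the series, on what has been measured and on what is new or still open speak of the compounds shown alone.

The measured compounds are compound 1 `Cc1ccc(-n2cc(CNC(=O)c3cccc4c3cnn4C(C)C)nn2)c(C)c1` and compound 2 `CC(C)n1ncc2c(C(=O)NCc3cn(-c4ccc(F)cc4)nn3)cccc21`. In a functional assay on HepG2 cells (Homo sapiens) for inhibition, read by MTT assay, with a stated time of 72 h (on this read-out higher numbers stand for weaker inhibition and lower numbers for stronger inhibition), compound 1 gives > 40000 nM, which is a limit of the assay rather than a number. In this assay compound 2 gives > 40000 nM, again a limit. Going by the values given here, compound 2 thus stands only at a limit, and the one further value shown is a limit as well. The step that the two limits leave unreadable from compound 1 to compound 2 cannot be read, since both of its ends are limits.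

Compound 3 `CC(C)n1ncc2c(C(=O)NCc3cn(-c4cccc(Br)c4)nn3)cccc21` differs from compound 2 by 3-bromophenyl in place of 4-fluorophenyl on an aromatic nitrogen. Among the compounds with values here, no measured step bears on this change with a readable size; what the numbers show is the limit of > 40000 nM in this assay, at which 2 of the 2 values shown sit. For the step from compound 2 to compound 3 no direction can be drawn from the data. Compound 3 is therefore estimated at 40000 nM, with a range from 15000 nM to 200000 nM. The step of a number no higher from compound 2 to compound 3 (the limit leaves the size open) is expected to stay within the scatter, most likely as another limit.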

Compound 3, half-maximal inhibitory concentration: > 40000 nM
Compound 3: a limit, no number (the forecaster's own chance of this, stated with the estimate: 75%); the middle value sits exactly at the limit.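

In this assay compound 3 gives > 40000 nM, which is a limit of the assay. The steps to compound 3 from compound 1 and from compound 2 therefore cannot be read. The compounds shown leave open whether changing the group on the aromatic nitrogen alters inhibition at all: the limit of > 40000 nM in this assay, at which 3 of the 3 values shown sit.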